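Swapping the Aryl Group on a Ring Nitrogen

A few compounds are considered here, and "the series" means these few. Any claim that something is new, unique, unknown or untested is made for them only; others in the source may bear on it.

Measured so far:
Compound 1, `Nc1scc(CN2CCN(c3ccc([N+](=O)[O-])cc3)CC2)c1C(=O)c1ccc(Cl)cc1`, gives -17%.
Compound 2, `Nc1scc(CN2CCC(c3ccc(Cl)cc3)CC2)c1C(=O)c1ccc(Cl)cc1`, gives -61%.

Both numbers come from a functional assay on CHO cells with adenosine receptor A1 (Homo sapiens) as the target, read by cAMP accumulation and immunoassay, with a stated time of 6 min, tested at 10 uM; on this read-out lower numbers stand for a stronger effect and higher numbers for a weaker effect at the one concentration tested. On them compound 1 stands highest of the two, with compound 2 lying well lower, a gap beyond the usual scatter. Compound 3, `Nc1scc(CN2CCN(c3cccc(F)c3)CC2)c1C(=O)c1ccc(Cl)cc1`, differs from compound 1 in one place: 3-fluorophenyl in place of 4-nitrophenyl on an amine nitrogen in a ring. No such change has been measured here, so only a guarded expectation is possible: a small step downward, or none beyond the scatter, is expected, a number 13 percentage points lower from compound 1 to compound 3 (beyond the scatter). Compound 3 is therefore estimated at -30%, likely between -60% and 0%.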

Compound 3, a percentage reported as activity, at one concentration (the size of the read-out at that concentration, not a potency): -82%
Beside the measured number, compound 3's estimate is 52 percentage points above it, and the stated range ends above it.
By their numbers in this assay, from the lowest: compound 3; then compound 2; then compound 1.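

In this assay, the aryl group on this ring nitrogen proves to be a sensitive point: with the rest of the molecule unchanged, 3-fluorophenyl in place of 4-nitrophenyl gives a number 65 percentage points lower from compound 1 to compound 3 (beyond the scatter). The two earlier compounds differ in more than one place, so they could not isolate this change. Nothing available explains the size of this step. On these data alone, the swap alters both the substituent and where it sits on the phenyl ring, so their separate contributions remain open. A plain phenyl group on the same nitrogen would give a reference for both.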